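Chloro in Place of Bromo: Expected Liver Clearance

The source may hold more compounds than are shown below. What is called first, only, known or untested is meant among the compounds shown, and "the series" means these compounds.

Compound 1, `Brc1cccc2c1nnn2CC1CC1`: 0.6 mL/min/g
Compound 2, `Brc1cc(Br)c2nnn(CC3CC3)c2c1`: 2.3 mL/min/g

In an ADME assay on microsomes from liver (Rattus norvegicus, strain Wistar) for metabolic stability, tested at 2.5 uM (a lower number here means slower removal, a higher number faster removal of the compound), compound 2 gives 2.3 mL/min/g, the higher of the two numbers; compound 1 gives 0.6 mL/min/g. Among the measured compounds shown here, the single measured step, a 3.8-fold higher number from compound 1 to compound 2 (0.58 log units; beyond the scatter), came with bromo in place of hydrogen on an aromatic carbon, a modest rise beyond the scatter.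

Compound 3, `Clc1cc(Br)c2nnn(CC3CC3)c2c1`, differs from compound 2 by chloro in place of bromo on an aromatic carbon. For the measured compounds named here, no measured step exchanges one halogen for another, so the step from compound 1 to compound 2 bears only loosely on it: it shows that putting a halogen at this carbon raised removal, but not how chloro and bromo compare. A change of that kind is therefore expected to stay within the scatter.

For compound 3 in this assay a value of 1.9 mL/min/g is estimated, within 0.9 mL/min/g to 3.8 mL/min/g. That estimate means a step of a 1.2-fold lower number from compound 2 to compound 3 (0.08 log units; within the scatter), expected to lie within the scatter.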

Compound 3, intrinsic clearance in a liver preparation (reported as CLH), per the amount of preparation that the assay uses: 1.1 mL/min/g
Estimate against measurement, compound 3: 1.7-fold (0.24 log units) above; measured number inside the range.
By their numbers in this assay, from the lowest: compounds 1 and 3 (each within the scatter of the next); then compound 2.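

In this assay, the choice of halogen at this carbon makes a measurable difference, and chloro and bromo do not behave alike here (a modest step: a 2.1-fold lower number from compound 2 to compound 3 (0.32 log units; beyond the scatter)). Compared with hydrogen at the same carbon, chloro gives a change that stays inside the usual scatter (the step reads a 1.8-fold higher number from compound 1 to compound 3 (0.26 log units; within the scatter)), whereas bromo there stood clearly apart from hydrogen. Nothing in the available data explains why the two halogens differ.

With only hydrogen, chloro and bromo shown at this carbon, it remains open how a fluoro, a methyl or a methoxy group would fare there. Also open, going by these compounds, is whether chloro would give the same result if the remaining bromo group on the ring were replaced by another group, such as an amine.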